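This account rests on a few compounds, and the source may have more. Where it says the series, first, only, none or still open, it means among the compounds named here.

Among the compounds with values here, compound 1 `FC(F)(F)c1cnc(N2CCC(NC(=S)Nc3cccnc3)CC2)c(Cl)c1` is the stronger of the two compounds measured so far. In an assay on membranes from brain for binding affinity to Lysophosphatidylserine lipase ABHD12 (Mus musculus), read by fluorescence, with a stated time of 20 min, tested at 10 uM (a higher number here means a stronger effect of the compound at the concentration tested, a lower number a weaker effect), compound 1 gives 96%, the highest of the two numbers shown. Within the data shown here, its only neighbour is compound 2 `COc1ccc(NC(=S)NC2CCN(c3ncc(C(F)(F)F)cc3Cl)CC2)cn1`, which in this assay gives 1%; the step of a number 95 percentage points lower from compound 1 to compound 2 (beyond the scatter) is a large one and comes from a methoxy in place of hydrogen on an aromatic carbon.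

Compound 3 `CN(C(=S)Nc1cccnc1)C1CCN(c2ncc(C(F)(F)F)cc2Cl)CC1` has not yet been measured in this assay. Among the measured compounds shown here, it differs from compound 1 by methyl in place of hydrogen on an amide-type nitrogen, the nitrogen in question being the one whose other neighbours are a saturated ring carbon and a thiocarbonyl carbon. For the measured compounds named here, no measured step touches this nitrogen, so nothing measured bears directly on the change; the step from compound 1 to compound 2 shows only that a single small change elsewhere on the shared core can wipe out the whole effect, which makes the scale of possible outcomes wide. On that basis a downward step is expected for compound 3, of size a number 46 percentage points lower from compound 1 to compound 3 (beyond the scatter), though with little confidence in its size. Compound 3 is accordingly estimated at 50% in this assay, within a range from 5% to 95%.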

Compound 3, a percentage reported as inhibition, at one concentration (the size of the read-out at that concentration, not a potency): 61%
Beside the measured number, compound 3's estimate is 11 percentage points below it; the range from low to high includes it.
By their numbers in this assay, from the lowest: compound 2; then compound 3; then compound 1.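

In this assay, within the data shown here, the change gives a number 35 percentage points lower from compound 1 to compound 3 (beyond the scatter), the first measured step at the amide-type nitrogen whose other neighbours are a saturated ring carbon and a thiocarbonyl carbon. The step is large, yet the effect is not abolished: with methyl in place of hydrogen on this nitrogen, compound 3 still gives 61%, so the hydrogen at this position is not strictly required for a substantial read-out at the single concentration tested. No measurement available here explains why the number falls or why so much of the effect remains.

The compounds shown leave open whether an ethyl group, a longer chain or a hydroxyethyl group on the same nitrogen would lower the number further or leave it close to that of compound 3. They also cannot separate the loss of the hydrogen from the presence of the added carbon, and as the read-out comes from one concentration, they do not show how far compound 3 differs from compound 1 in potency.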